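Methoxy added back to the lower compound

This account rests on a few compounds, and the source may have more. Where it says the series, first, only, none or still open, it means among the compounds named here.

Compound 2 `COc1cc(/C=C/C(=O)/C=C/c2ccccc2)ccc1OCc1cn(CCOc2cc(=O)oc3ccccc23)nn1` stands lowest of the two measured compounds: in a functional assay on COLO 205 cells (Homo sapiens) for inhibition, read by sulforhodamine B assay, with a stated time of 48 h, tested at 50 uM (a lower number here means less inhibition of growth, a higher number more inhibition of growth at the concentration tested), compound 2 gives 54% and compound 1 `COc1cccc(/C=C/C(=O)/C=C/c2ccc(OCc3cn(CCOc4cc(=O)oc5ccccc45)nn3)c(OC)c2)c1` gives 69% under the same conditions. The change to compound 3 `COc1ccc(/C=C/C(=O)/C=C/c2ccc(OCc3cn(CCOc4cc(=O)oc5ccccc45)nn3)c(OC)c2)cc1` is methoxy in place of hydrogen on an aromatic carbon and sits para to a large group. Going by the values given here, the one measured step bearing on it is a number 15 percentage points lower from compound 1 to compound 2 (beyond the scatter) for hydrogen in place of methoxy, the same exchange in reverse but not at the same place. In this assay a rise of similar or somewhat smaller size is therefore expected, estimated as a number 11 percentage points higher from compound 2 to compound 3 (beyond the scatter) for this change. Compound 3 is expected at 65% within 52% to 78% as its estimated range.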

Compound 3, percent growth inhibition at one concentration: 68%
For compound 3 the middle estimate is 3 percentage points below the measured one; the measured number falls inside the stated range.
By their numbers in this assay, from the lowest: compound 2; then compounds 3 and 1 (each within the scatter of the next).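

Phenyl to 4-methoxyphenyl gives a number 14 percentage points higher from compound 2 to compound 3 (beyond the scatter) in this assay, so the gain seen with the 3-methoxyphenyl group also appears with methoxy on the aromatic carbon para to a large group. Exchanging 3-methoxyphenyl for 4-methoxyphenyl gives a number 1 percentage points lower from compound 1 to compound 3 (within the scatter), so these two methoxy placements do not separate in this assay. Nothing available accounts for the gain from methoxy.

Open, as far as these compounds go, is whether the gain is specific to methoxy: a hydroxyl, an amine or a longer ethoxy chain at this place would test that. These readings also leave open how the compounds rank across a range of concentrations.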